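Indolyl to Nitrophenyl on the Hydrazone Carbon

The source may hold more compounds than are shown below. What is called first, only, known or untested is meant among the compounds shown, and "the series" means these compounds.

Three analogues sharing one core have been measured in a functional assay on MGC-803 cells (Homo sapiens) for antiproliferative activity, read by MTT assay, with a stated time of 72 h; a lower number here means a stronger inhibitor, a higher number a weaker inhibitor. Compound 1 `CCCSc1nc(N/N=C/c2ccc(C)cc2)c2nnn(Cc3ccccc3)c2n1` carries a 4-methylphenyl on the carbon with a double bond to nitrogen, and in this assay compound 1 gives only a limit, > 64000 nM (the limit of > 64000 nM in this assay, at which 1 of the 3 values shown sits). Compound 2 `CCCSc1nc(N/N=C/c2ccccc2Cl)c2nnn(Cc3ccccc3)c2n1` gives 10900 nM in this assay, and compound 3 `CCCSc1nc(N/N=C/c2c[nH]c3ccccc23)c2nnn(Cc3ccccc3)c2n1` gives 7410 nM. The step of an at least 5.8-fold lower number from compound 1 to compound 2 (0.76 log units; beyond the scatter) and the step of an at least 8.6-fold lower number from compound 1 to compound 3 (0.93 log units; beyond the scatter) both go beyond the scatter, whereas a 1.5-fold lower number from compound 2 to compound 3 (0.17 log units; within the scatter) does not. Compound 3 therefore holds the lowest of the two numbers, with compound 2 close by and the third value a limit. Compound 4 `CCCSc1nc(N/N=C/c2ccc([N+](=O)[O-])cc2)c2nnn(Cc3ccccc3)c2n1` differs from compound 3 in one place: 4-nitrophenyl in place of 1H-indol-3-yl on a carbon with a double bond to nitrogen. Within the data shown here, no measured step pairs a 4-nitrophenyl with any other group, so the bearing steps are indirect. The step of a 1.5-fold lower number from compound 2 to compound 3 (0.17 log units; within the scatter) shows that two different aromatic groups on this carbon can sit within the scatter of each other. On the other hand, compound 1, whose group is also a six-membered aromatic ring of carbon only, gave only a limit in this assay. The expectation is a modest rise in the number, a 2.2-fold higher number from compound 3 to compound 4 (0.33 log units; beyond the scatter), with wide uncertainty. Compound 4 is therefore estimated at 16000 nM, within 4000 nM to 64000 nM.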

Compound 4, half-maximal inhibitory concentration: 10100 nM
Beside the measured number, compound 4's estimate is 1.6-fold (0.20 log units) above it, within the range that was stated.
By their numbers in this assay, from the lowest: compounds 3, 4 and 2 (each within the scatter of the next). At a limit, above all of these: compound 1.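

With 4-nitrophenyl on the carbon with a double bond to nitrogen, a 1.4-fold higher number from compound 3 to compound 4 (0.13 log units; within the scatter) and a 1.1-fold lower number from compound 2 to compound 4 (0.03 log units; within the scatter) in this assay, so three quite different aromatic groups at this position now lie within the scatter of one another. Among these compounds, compound 1 and compound 4 differ in a single substituent, which the earlier compounds did not allow to be isolated: with nitro in place of methyl on an aromatic carbon, the result is an at least 6.3-fold lower number from compound 1 to compound 4 (0.80 log units; beyond the scatter). A six-membered aromatic ring of carbon only is thus compatible with a measurable number here, and what sets compound 1 apart among these four is its methyl, although the size of that step remains open-ended, as compound 1 gives only a limit and not a number: the limit of > 64000 nM in this assay, at which 1 of the 4 values shown sits.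

The compounds shown leave open how an unsubstituted phenyl, an amine or a carboxylic acid would behave on this ring, and so whether the methyl stands alone in this assay or marks a wider trend. They also leave open whether any group at this position can move the number well beyond the band shared by compound 2, compound 3 and compound 4.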